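Flipping One Stereocentre: What to Expect of Compound 4

This account rests on a few compounds, and the source may have more. Where it says the series, first, only, none or still open, it means among the compounds named here.

In an ADME assay on MDCK cells (Canis lupus familiaris) for permeability, in the apical to basolateral direction (on this read-out lower numbers stand for lower permeability and higher numbers for higher permeability), compound 1 (`CC(C)[C@@H](c1ccc(-c2ccc3cccc(F)c3c2)[nH]c1=O)[C@@H]1OC(=O)NC1=O`) gives 3.15 10^-6 cm/s and compound 2 (`CC(C)[C@@H](c1ccc(-c2ccc3cccc(F)c3c2)[nH]c1=O)[C@H]1OC(=O)NC1=O`) gives 9.14 10^-6 cm/s. Compound 3 (`CC(C)[C@H](C[C@H]1SC(=O)NC1=O)c1ccc(-c2ccc3cccc(F)c3c2)[nH]c1=O`) carries (2,4-dioxo-1,3-thiazolidin-5-yl)methyl in place of 2,4-dioxo-1,3-oxazolidin-5-yl, and it gives 17.6 10^-6 cm/s. That is a 5.6-fold higher number from compound 1 to compound 3 (0.75 log units; beyond the scatter), but also a 1.9-fold higher number from compound 2 to compound 3 (0.28 log units; within the scatter), so compound 3 shares the top of this small set with compound 2.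

Compound 4 (`CC(C)[C@@H](C[C@H]1SC(=O)NC1=O)c1ccc(-c2ccc3cccc(F)c3c2)[nH]c1=O`) is related to compound 3 as follows: the two compounds have the same atoms and bonds and differ only in configuration as drawn: 1 of 2 stereo elements differ; a stereocentre at a saturated chain carbon is drawn S in compound 3 and R in compound 4. Going by the values given here, the closest precedent is a 2.9-fold higher number from compound 1 to compound 2 (0.46 log units; beyond the scatter), which comes with the fact that compounds 1 and 2 differ only in the configuration as drawn. That pair differs at a saturated ring carbon rather than a saturated chain carbon, so it hints at the possible size of such a change but not at its direction here. In this assay, among the compounds with values here, a shift no larger than that precedent seems likely, and perhaps none beyond the scatter. The expected change is a 1.5-fold lower number from compound 3 to compound 4 (0.17 log units; within the scatter). For compound 4 the estimated value is 12 10^-6 cm/s, with an expected range of 5 10^-6 cm/s to 26 10^-6 cm/s.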

Compound 4, apparent permeability: 25.5 10^-6 cm/s
Compound 4: the middle estimate sits 2.1-fold (0.33 log units) below what was measured; the measured number falls inside the stated range.
By their numbers in this assay, from the lowest: compound 1; then compounds 2, 3 and 4 (each within the scatter of the next, the first and the last beyond it).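

In this assay, the step at the saturated chain carbon is a 1.4-fold higher number from compound 3 to compound 4 (0.16 log units; within the scatter), so the two configurations at this position cannot be told apart in this read-out. That differs from the flip at the saturated ring carbon, a 2.9-fold higher number from compound 1 to compound 2 (0.46 log units; beyond the scatter), which shows that in these two pairs a change of configuration does not carry the same weight at each position. The comparison is clean at this position, with a single point separating the pair: the fact that compounds 3 and 4 differ only in the configuration as drawn.

The compounds shown leave open whether the saturated ring carbon in the (2,4-dioxo-1,3-thiazolidin-5-yl)methyl group matters here as the ring carbon did in compounds 1 and 2. They also leave open whether the chain carbon would stay this indifferent with a carboxylic acid in place of that group.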